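The compounds below may be only part of what the source reports. "The series", "measured", "known", "first", "only" and "open" are said of these compounds alone.

Of the compounds shown here, three have been measured in a functional assay on MCF7 cells (Homo sapiens) for inhibition; on this read-out lower numbers stand for stronger inhibition and higher numbers for weaker inhibition. Compound 1 `CS(=O)(=O)c1ccc2nc(-c3ccc(O)cc3)sc2c1` gives 62300 nM, compound 2 `COc1ccc(-c2nc3cc(F)ccc3s2)cc1F` gives 870 nM, and compound 3 `COc1cc(OC)cc(-c2nc3cc(F)ccc3s2)c1` gives 1230 nM. Compound 3 therefore holds the second highest of the three numbers. Its value lies within the scatter of the value of compound 2, so the two cannot be ranked, while compound 1 stands far higher, well beyond the scatter.

The next compound to be tested is compound 4 `COc1cc(-c2nc3cc(F)ccc3s2)cc(OC)c1OC`. It differs from compound 3 by a single change, with methoxy in place of hydrogen on an aromatic carbon, ortho to two methoxy groups and para to a large group: methoxy in place of hydrogen on an aromatic carbon.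

Going by the values given here, no two measured compounds differ in only one place, so the data offer no direct precedent for this change. The closest guide is that compound 2 at 870 nM and compound 3 at 1230 nM sit within the scatter of each other despite their different substitution. In this assay, no step beyond the scatter is therefore expected, and the direction remains uncertain. The estimated step is a 1.2-fold lower number from compound 3 to compound 4 (0.09 log units; within the scatter), which is expected to stay within the scatter. For compound 4 the expected value is 1000 nM, with an estimated range from 200 nM to 5000 nM.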

Compound 4, half-maximal inhibitory concentration: 1.9 nM
For compound 4 the middle estimate is 530-fold (2.72 log units) above the measured one, and the stated range ends above it.
By their numbers in this assay, from the lowest: compound 4; then compounds 2 and 3 (each within the scatter of the next); then compound 1.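

In this assay, going by these compounds alone, the single change of hydrogen to methoxy brings a 650-fold lower number from compound 3 to compound 4 (2.81 log units; beyond the scatter) and gives the first step between measured compounds that differ in one place. It shows that this aromatic carbon, ortho to two methoxy groups and para to a large group, is highly sensitive to substitution: adding one methoxy, with 2 heavy atoms and 1 hydrogen-bond acceptor, is enough to produce a large drop in the number. No measurement presented here accounts for the size of this step, so it stands as an observation without an explanation.

Going by these compounds, with only hydrogen and methoxy seen at this carbon, it remains open whether the step is specific to methoxy or would also appear with ethoxy, chlorine or an amine in the same place. Within the data shown here, it is also open whether the same change would have a comparable effect without the two methoxy groups already present on that ring, as only one such pair of compounds is available.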